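Working notes: from compound 3 to compound 4

The source may report more compounds than this note shows. Statements on the series, on what has been measured and on what is new or still open speak of the compounds shown alone.

Measured in a functional assay on HL-60 cells (Homo sapiens) for cytotoxicity, read by WST assay, with a stated time of 48 h; on this read-out lower numbers stand for an effect already at smaller amounts and higher numbers for an effect only at larger amounts of compound:
- compound 1 `O=C1OC[C@H](Cc2ccccc2)[C@H]1Cc1ccccc1C(F)(F)F`: 37000 nM
- compound 2 `O=C1OC[C@H](Cc2ccccc2)[C@H]1Cc1ccc(Cl)cc1`: 36000 nM
- compound 3 `Clc1ccc(C[C@H]2COC[C@@H]2Cc2ccccc2)cc1Cl`: 19000 nM

Compound 3 stands within the scatter of both compound 1 and compound 2, so the three values do not separate. Compound 4 `Oc1ccccc1C[C@H]1COC[C@@H]1Cc1ccc(Cl)c(Cl)c1` follows from compound 3 through (hydroxy in place of hydrogen on an aromatic carbon), a phenyl to 2-hydroxyphenyl change. For the measured compounds named here, no measured pair differs in one place only, so the data offer no direct guide to this change. The expected 1.6-fold lower number from compound 3 to compound 4 (0.20 log units; within the scatter) is small, towards a lower number in this assay, and possibly none beyond the scatter. For compound 4 the estimated value is 12000 nM, with an expected range of 4000 nM to 35000 nM.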

Compound 4, half-maximal effective concentration: 34000 nM
The estimate for compound 4 lay 2.8-fold (0.45 log units) below the measured number; the range from low to high includes it.
By their numbers in this assay, from the lowest: compounds 3, 4, 2 and 1 (each within the scatter of the next).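

In this assay hydroxy in place of hydrogen on an aromatic carbon, ortho to a large group, gives a 1.8-fold higher number from compound 3 to compound 4 (0.25 log units; within the scatter) and so stays within the scatter. For the compounds shown here, this is the first step that differs in one place, and it does not separate 2-hydroxyphenyl from phenyl at this position. Nothing on hand offers an explanation for this result. Going by these compounds, whether an amine or a methoxy group at the same place would give a step beyond the scatter remains open.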